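A few compounds are considered here, and "the series" means these few. Any claim that something is new, unique, unknown or untested is made for them only; others in the source may bear on it.

Measured so far:
- compound 1 `CCOC(=O)N1N=C(c2ccccc2)CC1c1cc(OC)c(OC)c(OC)c1`: 8230 nM
- compound 2 `CCCOC(=O)N1N=C(c2ccccc2)CC1c1cc(OC)c(OC)c(OC)c1`: > 10000 nM (a limit of the assay, not a number)

Among the measured compounds shown here, in a functional assay on HeLa cells (Homo sapiens) for antiproliferative activity, read by MTT assay, with a stated time of 48 h (on this read-out higher numbers stand for weaker inhibition of growth and lower numbers for stronger inhibition of growth), compound 1 gives 8230 nM, the only true number so far. Compound 3 `CCOC(=O)N1N=C(c2cccc(O)c2)CC1c1cc(OC)c(OC)c(OC)c1` differs from it by hydroxy in place of hydrogen on an aromatic carbon, with hydroxy in place of hydrogen on an aromatic carbon. For the measured compounds named here, the one measured step, an at least 1.2-fold higher number from compound 1 to compound 2 (0.08 log units; that floor lies within the scatter), lies on a saturated chain, not on the aromatic ring, so it bears only weakly on this change. No direction can be drawn from it, and no shift beyond the scatter is expected. The estimated step is a 1.2-fold lower number from compound 1 to compound 3 (0.07 log units; within the scatter). For compound 3 the expected value is 7000 nM, with an estimated range of 2000 nM to 25000 nM.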

Compound 3, concentration for 50% growth inhibition: 3280 nM
The estimate for compound 3 lay 2.1-fold (0.33 log units) above the measured number, and the stated range covers the measured number.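

Placing hydroxy on the aromatic ring, meta to a large group, is the first change shown here that clearly moves the result in this assay (a 2.5-fold lower number from compound 1 to compound 3 (0.40 log units; beyond the scatter)). This place on the ring therefore responds to substitution, and with hydroxy the response is a modest gain in growth inhibition. Nothing measured here accounts for that gain. Still open, on these data alone, is whether an amine or a methoxy group at the same place would act like hydroxy. The compounds shown also do not tell whether hydroxy elsewhere on this ring would give a similar gain.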